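Sulfonyl substituent and buffer solubility in the urea series

The source may hold more compounds than are shown below. What is called first, only, known or untested is meant among the compounds shown, and "the series" means these compounds.

Compound 1 `O=C(NCc1ccc(S(=O)(=O)c2cc(F)cc(F)c2)cc1)N1Cc2ccncc2C1` carries a 3,5-difluorophenyl on the sulfonyl sulfur. Within the data shown here, in a physicochemical assay for solubility, in phosphate buffer, with a stated time of 24 h, at pH 7.4, tested at 100 uM (a higher number here means a more soluble compound, a lower number a less soluble compound), compound 1 gives 16000 nM, the lowest of the three numbers so far. Compound 2 `O=C(NCc1ccc(S(=O)(=O)C2CCOCC2)cc1)N1Cc2ccncc2C1` gives 206000 nM in this assay, and compound 3 `O=C(NCc1ccc(S(=O)(=O)C2CCN(C3COC3)CC2)cc1)N1Cc2ccncc2C1` gives 121000 nM. The two measured steps away from compound 1 both move the same way: a 13-fold higher number from compound 1 to compound 2 (1.11 log units; beyond the scatter) and a 7.6-fold higher number from compound 1 to compound 3 (0.88 log units; beyond the scatter). Between the two saturated rings the gap is small: a 1.7-fold lower number from compound 2 to compound 3 (0.23 log units; within the scatter).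

Compound 4 `O=C(NCc1ccc(S(=O)(=O)N2CCC[C@H](O)C2)cc1)N1Cc2ccncc2C1` is not yet measured. The change from compound 1 is 3-hydroxypiperidin-1-yl in place of 3,5-difluorophenyl on a sulfonyl sulfur. The steps to compound 2 and compound 3 bear on it, as each replaces the 3,5-difluorophenyl with a saturated ring, and each gave a rise beyond the scatter. A rise of similar size is therefore expected for compound 4, a 9.4-fold higher number from compound 1 to compound 4 (0.97 log units; beyond the scatter). The estimate for compound 4 in this assay is 150000 nM, with a range from 50000 nM to 400000 nM.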

Compound 4, solubility: 215000 nM
Compound 4: middle estimate off by 1.4-fold (0.16 log units), on the low side; measured number inside the range.
By their numbers in this assay, from the lowest: compound 1; then compounds 3, 2 and 4 (each within the scatter of the next).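

Placing 3-hydroxypiperidin-1-yl on the sulfonyl sulfur in place of 3,5-difluorophenyl gives a large step (a 13-fold higher number from compound 1 to compound 4 (1.13 log units; beyond the scatter)), so the rise seen with the two earlier saturated rings also holds for a ring attached through its nitrogen and carrying a hydroxyl. The saturated rings do not separate at this position, with (a 1.8-fold higher number from compound 3 to compound 4 (0.25 log units; within the scatter)) and (a 1.0-fold higher number from compound 2 to compound 4 (0.02 log units; within the scatter)) both printed as within the scatter, leaving compound 1 alone apart from compounds 2, 3 and 4. The data shown offer no explanation for the rise.

Open, on these data alone, is whether an unsubstituted piperidin-1-yl would stand with these rings, which would separate the contribution of the hydroxyl from that of the ring. Also open, as far as these compounds go, is whether a pyridyl on the sulfonyl sulfur would stand with compound 1 or with the saturated rings.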